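This account rests on a few compounds, and the source may have more. Where it says the series, first, only, none or still open, it means among the compounds named here.

Measured so far in a functional assay on BXPC-3 cells (Homo sapiens) for cytotoxicity, read by MTT assay, with a stated time of 72 h; a higher number here means a weaker inhibitor, a lower number a stronger inhibitor:
- compound 1 `Nc1ccc(-c2ccc(NC3=CC(=O)c4ncncc4C3=O)cc2)cc1` gives 3500 nM
- compound 2 `CCc1ccc(-c2ccc(NC3=CC(=O)c4ncncc4C3=O)cc2)cc1` gives 3100 nM

Going by the values given here, compound 2 stands level with compound 1, the only other measured compound, and their two values lie within the scatter of each other. Among the compounds with values here, the one measured step, a 1.1-fold lower number from compound 1 to compound 2 (0.05 log units; within the scatter), is small.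

Compound 3 `CCOC(=O)c1ccc(NC2=CC(=O)c3ncncc3C2=O)cc1` has not yet been measured. It keeps the shared core, but its structure departs from compound 2 with ethoxycarbonyl in place of 4-ethylphenyl on an aromatic carbon, (ethoxycarbonyl in place of 4-ethylphenyl on an aromatic carbon), para to a large group.

The measured step bears on this only loosely. It exchanged one group for another on a ring that compound 1 and compound 2 both keep, whereas here that ring leaves. Within the data shown here, no measured compound lacks it, so the data give no direct size or direction for such a change. In this assay no step beyond the scatter can therefore be expected, although the uncertainty is wide. The estimated step is a 1.0-fold lower number from compound 2 to compound 3 (0.01 log units; within the scatter) in size. For compound 3 the expected value is 3000 nM, with an estimated range from 1000 nM to 9000 nM for this measurement.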

Compound 3, half-maximal inhibitory concentration: 5900 nM
Compound 3: middle estimate off by 2.0-fold (0.29 log units), on the low side, and the stated range covers the measured number.
By their numbers in this assay, from the lowest: compounds 2, 1 and 3 (each within the scatter of the next).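

Going by these compounds alone, the earlier compounds only varied a group on the outer ring, whereas compound 3 is the first to lack that ring, with ethoxycarbonyl in place of 4-ethylphenyl on an aromatic carbon para to a large group. In this assay, this exchange gives a 1.9-fold higher number from compound 2 to compound 3 (0.28 log units; within the scatter), and the matching exchange of 4-aminophenyl for ethoxycarbonyl gives a 1.7-fold higher number from compound 1 to compound 3 (0.23 log units; within the scatter), so across these three compounds neither loss of the ring nor the arrival of an ester with its hydrogen-bond acceptors moves the number beyond the scatter. Cytotoxicity at this position therefore does not depend on the outer ring in these compounds, and all three sit at similar values; no measured information is available that would explain this.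

The compounds shown leave open how a carboxylic acid, an amide or a longer alkyl ester would read at this position, since ethoxycarbonyl is the only group without a ring among them. They also leave open what a small group such as methyl or a plain amine would give there, and whether any change at this position can move the number beyond the scatter.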